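This account rests on a few compounds, and the source may have more. Where it says the series, first, only, none or still open, it means among the compounds named here.

Measured in a functional assay (strain AB) with Danio rerio as the target, read by microscopy, with a stated time of 1 h; on this read-out lower numbers stand for an effect already at smaller amounts and higher numbers for an effect only at larger amounts of compound:

- Compound 1 `CCN1CCc2c(sc(NC(=O)Nc3ccc(Cl)cc3)c2C(N)=O)C1`: 3120 nM
- Compound 2 `CCN1CCc2c(sc(NC(=O)Nc3ccc(Cl)cc3)c2C#N)C1`: > 25000 nM
- Compound 3 `CCN1CCc2c(sc(NC(=O)Nc3ccc(Cl)cc3)c2C(=O)NC)C1`: > 25000 nM

Compound 3 gives > 25000 nM, which is a limit of the assay and not a number. Compound 3 thus stands at the limit of > 25000 nM in this assay, at which 2 of the 3 values shown sit, and only compound 1 gives a true number.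

Compound 4 `CCN1CCc2c(sc(NC(=O)Nc3ccc(Cl)cc3)c2C(=O)O)C1` carries hydroxy in place of methylamino on a carbonyl carbon, so methylcarbamoyl becomes carboxy. For the measured compounds named here, no measured step makes this exact change. The closest evidence is an at least 8.0-fold higher number from compound 1 to compound 3 (0.90 log units; beyond the scatter) and an at least 8.0-fold higher number from compound 1 to compound 2 (0.90 log units; beyond the scatter). Both steps leave the carbamoyl group of compound 1, and both end at the limit. The a step that the two limits leave unreadable from compound 2 to compound 3 adds nothing further.

Compound 4 also lacks that carbamoyl group, which so far is found only in compound 1 at 3120 nM. The expected change is a number no higher from compound 3 to compound 4 (the limit leaves the size open), meaning no readable step, and a report of only a limit is the likeliest outcome. For compound 4, the estimated value is 25000 nM, with an expected range from 8000 nM to 50000 nM.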

Compound 4, half-maximal effective concentration: > 25000 nM
Compound 4: only a limit was reported; the forecaster's own chance of this, stated with the estimate: 80%; the middle value sits exactly at the limit.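

Hydroxy in place of amino on the carbonyl carbon gives a third change to the carbamoyl group of compound 1 that ends at a limit in this assay, here with an at least 8.0-fold higher number from compound 1 to compound 4 (0.90 log units; beyond the scatter). A carbonyl carbon in this place is thus not enough for a readable effect, since compound 3 and compound 4 both keep one and neither gives a true number; among the compounds shown, only the carbamoyl group of compound 1 does. The steps among compound 2, compound 3 and compound 4 cannot be read, because all of them join two limits: the limit of > 25000 nM in this assay, at which 3 of the 4 values shown sit.

On these data alone, how far these three compounds lie from one another stays open. As far as these compounds go, it is also open whether a sulfonamide or an aminomethyl group in this place would give a true number.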